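The source may hold more compounds than are shown below. What is called first, only, known or untested is meant among the compounds shown, and "the series" means these compounds.

Measured compounds:
Compound 1, `CC1(C[C@@H](O)C(=O)N2[C@@H]3C[C@@H]3C[C@H]2C(=O)NCc2cc(Cl)ccc2-n2cnnn2)CC1`: 1300 nM
Compound 2, `O=C(NCc1cc(Cl)ccc1-n1cnnn1)[C@@H]1CC=NN1C(=O)[C@H](O)Cc1ccccc1`: 1400 nM

In a functional assay on a cell-free system (plasma, Homo sapiens), with a stated time of 3 min (on this read-out higher numbers stand for weaker inhibition and lower numbers for stronger inhibition), compound 1 gives 1300 nM. In this assay compound 2 gives 1400 nM. Among the measured compounds shown here, the two numbers lie within the scatter of one another, so compound 1 stands level with compound 2 on what has been measured; no step between them can be read.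

Compound 3, `CC(C)(C)C[C@@H](O)C(=O)N1[C@@H]2C[C@@H]2C[C@H]1C(=O)NCc1cc(Cl)ccc1-n1cnnn1`, is not yet measured. It differs from compound 1 in one place: tert-butyl in place of 1-methylcyclopropyl on a saturated chain carbon, two bonds along the chain from a carbonyl carbon and an oxygen on a saturated carbon. Both groups carry the same count of carbon atoms and neither brings a donor, an acceptor or a charge; the change sits two bonds along the chain from a carbonyl carbon and an oxygen on a saturated carbon.

For the measured compounds named here, with no step between measured compounds to draw on, compound 3 is expected to stay close to compound 1, a step of no change at the digits printed from compound 1 to compound 3 (within the scatter) being anticipated, none beyond the scatter. Compound 3 is estimated at 1300 nM, within 500 nM to 3500 nM.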

Compound 3, half-maximal inhibitory concentration: 520 nM
Estimate against measurement, compound 3: 2.5-fold (0.40 log units) above; the range from low to high includes it.
By their numbers in this assay, from the lowest: compound 3; then compounds 1 and 2 (each within the scatter of the next).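

In this assay the position on a saturated chain carbon, two bonds along the chain from a carbonyl carbon and an oxygen on a saturated carbon, turns out to respond to the group it carries: tert-butyl in place of 1-methylcyclopropyl gives a 2.5-fold lower number from compound 1 to compound 3 (0.40 log units; beyond the scatter) as a modest step beyond the scatter. The two groups have the same count of heavy atoms, all carbon, and neither has a hydrogen-bond donor or acceptor or a net charge, so these counts do not separate them; only 1-methylcyclopropyl holds a three-membered ring. Nothing measured here explains the step.

The compounds shown leave open how an isopropyl group, a cyclobutyl group or a longer chain ending in an amine would fare at this position. They also leave open whether the same change would give a similar step on the core of compound 2.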